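Aryl urea series: bromo in place of hexyl

The source may hold more compounds than are shown below. What is called first, only, known or untested is meant among the compounds shown, and "the series" means these compounds.

Measured compounds in an ADME assay on the whole organism with Oryza sativa as the target, tested at 1 uM; on this read-out lower numbers stand for a stronger effect and higher numbers for a weaker effect at the one concentration tested:
compound 1 `CCc1ccc(NC(=O)N[C@@H](C)c2ccccc2)cc1` gives 95%
compound 2 `CC(C)c1ccc(NC(=O)N[C@@H](C)c2ccccc2)cc1` gives 96%
compound 3 `CCCCCCc1ccc(NC(=O)N[C@@H](C)c2ccccc2)cc1` gives 100%

Compound 3 holds the highest of the three numbers, but its nearest neighbour is compound 2 at a number 4 percentage points higher from compound 2 to compound 3 (within the scatter), and compound 1 lies at a number 5 percentage points higher from compound 1 to compound 3 (within the scatter); both gaps are within the scatter, so the three compounds cannot be ranked. The remaining step, a number 1 percentage points higher from compound 1 to compound 2 (within the scatter), is also within the scatter. Across the three, changing the size of the saturated chain on the aromatic carbon did not move the read-out beyond noise.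

Compound 4 `C[C@H](NC(=O)Nc1ccc(Br)cc1)c1ccccc1` is not yet measured. Its change from compound 3 is bromo in place of hexyl on an aromatic carbon. For the measured compounds named here, no measured step swaps a chain for a halogen, so none bears directly on this change; the three known steps only show that the read-out stayed flat while the group on that aromatic carbon varied. On that basis no step beyond the scatter is expected, and the estimate for compound 4 is 96%, within 86% to 100%, which means an expected step of a number 4 percentage points lower from compound 3 to compound 4 (within the scatter).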

Compound 4, a percentage reported as activity, at one concentration (the size of the read-out at that concentration, not a potency): 97%
Estimate against measurement, compound 4: 1 percentage points below, and the stated range covers the measured number.
By their numbers in this assay, from the lowest: compounds 1, 2, 4 and 3 (each within the scatter of the next).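

Notes on the aromatic carbon that carries the varied group, read in this assay: the earlier compounds varied only saturated chains here, and compound 4 extends the flat picture to a halogen. Bromo in place of hexyl (a number 3 percentage points lower from compound 3 to compound 4 (within the scatter)), bromo in place of isopropyl (a number 1 percentage points higher from compound 2 to compound 4 (within the scatter)) and bromo in place of ethyl (a number 2 percentage points higher from compound 1 to compound 4 (within the scatter)) all leave the read-out within the scatter, so neither replacing carbon with bromine at this place nor going from 6 heavy atoms to 1 heavy atom separates compound 4 from the other three compounds. No supporting data bear on why the read-out stays flat through this change.

On these data alone, all four compounds remain within the scatter of one another at the one concentration tested, so it remains open whether any group on this aromatic carbon can move the read-out beyond the scatter. As far as these compounds go, an amine or a carboxylic acid here would bring in hydrogen-bond donors or acceptors, which neither hexyl nor bromo has, and how either would read in this assay remains unknown.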